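Isobutyl in place of methyl on a known alpha-1 scaffold

The source may hold more compounds than are shown below. What is called first, only, known or untested is meant among the compounds shown, and "the series" means these compounds.

Measured so far in an assay on Prostate gland (Oryctolagus cuniculus) for inhibition of Adrenergic receptor alpha-1 (Homo sapiens); on this read-out lower numbers stand for tighter binding and higher numbers for weaker binding:
Compound 1 `COc1ccccc1N1CCN(CCCCOc2ccc(C(=O)Nc3ccccc3OCCCC(=O)O)cc2)CC1` gives 79.4 nM.
Compound 2 `COc1ccccc1N1CCN(CCC(Oc2ccc(NC(=O)c3ccccc3OCCCC(=O)O)cc2)c2ccccc2)CC1` gives 79.4 nM.
Compound 3 `COc1ccccc1N1CCN(CCC(Oc2ccc(NC(=O)c3ccccc3OCCCC(=O)O)cc2)c2ccc(C)cc2)CC1` gives 79.4 nM.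

Compound 3 stands level with compounds 1 and 2 in this assay; none of the three is set apart from the others. The next compound, compound 4 `COc1ccccc1N1CCN(CCC(Oc2ccc(NC(=O)c3ccccc3OCCCC(=O)O)cc2)c2ccc(CC(C)C)cc2)CC1`, differs from compound 3 by one change: isopropyl in place of hydrogen on a saturated chain carbon bound to an aromatic carbon. For the measured compounds named here, the only measured step that resembles this is the one from compound 2 to compound 3, which added a methyl and gave no change at the digits printed from compound 2 to compound 3 (within the scatter). Enlarging the same group further is therefore expected to leave this assay unchanged, a step of a 1.0-fold higher number from compound 3 to compound 4 (0.00 log units; within the scatter). Compound 4 is estimated at 80 nM, with a range from 30 nM to 250 nM.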

Compound 4, dissociation constant: 6310 nM
Beside the measured number, compound 4's estimate is 79-fold (1.90 log units) below it, outside the stated range (above it).
By their numbers in this assay, from the lowest: compounds 1, 2 and 3 (each within the scatter of the next); then compound 4.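

Going from 4-methylphenyl to 4-isobutylphenyl shows that this position does not tolerate every group in this assay: the step is a 79-fold higher number from compound 3 to compound 4 (1.90 log units; beyond the scatter), whereas methyl alone gave no change at the digits printed from compound 2 to compound 3 (within the scatter). Taken directly from hydrogen, the change to isobutyl gives a 79-fold higher number from compound 2 to compound 4 (1.90 log units; beyond the scatter), so binding survives a methyl here but is much weaker with an isobutyl. Nothing available explains this loss.

The compounds shown leave open where between methyl and isobutyl the loss sets in, which an ethyl or propyl group could show. They also leave open whether an amine here would fare differently.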